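A few compounds are considered here, and "the series" means these few. Any claim that something is new, unique, unknown or untested is made for them only; others in the source may bear on it.

Measured so far:
compound 1 `CS(=O)(=O)Nc1ccc2c(c1)S(=O)(=O)N=C(C1=C(O)C3CCCC3N(Cc3ccccn3)C1=O)N2` — in an in vitro ADME assay on microsomes from liver (Homo sapiens) for metabolic stability (a lower number here means that the compound disappears faster, a higher number that the compound lasts longer), compound 1 gives > 1 h, a limit of the assay.
compound 2 `CS(=O)(=O)Nc1ccc2c(c1)S(=O)(=O)N=C(C1=C(O)C3CCCC3N(Cc3ccc(F)cn3)C1=O)N2` — in this assay compound 2 gives > 1 h, a limit of the assay.
compound 3 `CS(=O)(=O)Nc1ccc2c(c1)S(=O)(=O)N=C(C1=C(O)[C@H]3CCCC[C@H]3N(Cc3ccc(F)cc3)C1=O)N2` — in this assay compound 3 gives > 1 h, a limit of the assay.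

Compound 2 therefore stands at the limit, and the same holds for every value shown here: the limit of > 1 h in this assay, at which 3 of the 3 values shown sit. Among the compounds with values here, the single measured step between compounds differing in one place, a step that the two limits leave unreadable from compound 1 to compound 2, runs between two limits and its size cannot be read.

Compound 4 `CC(C)CCN1C(=O)C(C2=NS(=O)(=O)c3cc(NS(C)(=O)=O)ccc3N2)=C(O)C2CCCC21` differs from compound 2 by isobutyl in place of 5-fluoropyridin-2-yl on a saturated chain carbon bound to an amide-type nitrogen in a ring. No measured step touches an isobutyl group in that place, and the one step that is shown is unreadable, so nothing in the data points to a direction or size for this change beyond the scatter. The estimate rests only on where compound 2 stands, and it is uncertain whether a number or again a limit will be reported.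

Compound 4 is expected in this assay to come out near 1 h, in the range 0.4 h to 2.5 h. The step this estimate means is a number no higher from compound 2 to compound 4 (the limit leaves the size open), expected to lie within the scatter.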

Compound 4, half-life: 0.167 h
Compound 4: middle estimate off by 6.0-fold (0.78 log units), on the high side; the measured number lies below the stated range.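

In this assay, within the data shown here, the group on the saturated chain carbon bound to the amide-type nitrogen in a ring gives the first readable change. Isobutyl in place of 5-fluoropyridin-2-yl gives an at least 5.9-fold lower number from compound 2 to compound 4 (0.77 log units; beyond the scatter), and isobutyl in place of pyridin-2-yl gives an at least 5.9-fold lower number from compound 1 to compound 4 (0.77 log units; beyond the scatter). The earlier compounds could not show that this place matters, and the full size of both steps stays open, because the starting values are limits of the assay: the limit of > 1 h in this assay, at which 3 of the 4 values shown sit.

The compounds shown do not separate the loss of the aromatic ring from the presence of the isopentyl chain itself. A cyclohexylmethyl group or a shorter chain such as ethyl in this place would bear on that question.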